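Swapping a Benzoyl for a Fluorinated Sulfonyl Group

The source may hold more compounds than are shown below. What is called first, only, known or untested is meant among the compounds shown, and "the series" means these compounds.

Compound 1 `O=S(=O)(NCCCNc1nccc(-c2c(-c3cccc(F)c3)nc3sccn23)n1)c1ccccc1` gives 6850 nM in a functional assay on SK-MEL-28 cells (Homo sapiens) for cytotoxicity, read by MTT assay; a lower number here means a stronger inhibitor, a higher number a weaker inhibitor.
Compound 2 `O=S(=O)(NCCNc1nccc(-c2c(-c3cccc(F)c3)nc3sccn23)n1)c1ccc(F)cc1` gives 9450 nM in this assay.
Compound 3 `O=C(NCCNc1nccc(-c2c(-c3cccc(F)c3)nc3sccn23)n1)c1ccccc1` gives 17000 nM in this assay.

Compound 3 holds the highest number of the three, though its gap to compound 2 is within the scatter; only a 2.5-fold higher number from compound 1 to compound 3 (0.39 log units; beyond the scatter) lies beyond it. Compound 4 `O=S(=O)(NCCNc1nccc(-c2c(-c3cccc(F)c3)nc3sccn23)n1)c1cccc(F)c1` differs from compound 3 in one place: (3-fluorophenyl)sulfonyl in place of benzoyl on an amine nitrogen. The measured step that bears on this is a 1.8-fold higher number from compound 2 to compound 3 (0.26 log units; within the scatter), which runs the opposite way, and compound 4 reverses it, the entering group being (3-fluorophenyl)sulfonyl rather than the (4-fluorophenyl)sulfonyl of compound 2. A step of about that size back toward the number of compound 2 is therefore expected, still within the scatter. Compound 4 is expected to give 9500 nM, in a range from 4500 nM to 19000 nM, meaning a 1.8-fold lower number from compound 3 to compound 4 (0.25 log units; within the scatter).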

Compound 4, half-maximal inhibitory concentration: 18300 nM
Beside the measured number, compound 4's estimate is 1.9-fold (0.28 log units) below it, within the range that was stated.
By their numbers in this assay, from the lowest: compounds 1, 2, 3 and 4 (each within the scatter of the next, the first and the last beyond it).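

In this assay, the change on this amine nitrogen gives a 1.1-fold higher number from compound 3 to compound 4 (0.03 log units; within the scatter) and so separates sulfonyl from benzoyl no better than compound 2 did, while 3-fluorophenyl in place of 4-fluorophenyl on the sulfonyl sulfur gives a 1.9-fold higher number from compound 2 to compound 4 (0.29 log units; within the scatter), so the two fluorine positions cannot be told apart either. Only a 2.7-fold higher number from compound 1 to compound 4 (0.43 log units; beyond the scatter) lies beyond the scatter. Nothing here explains these numbers.

That last step changes the chain and the fluorine together, so neither can be credited alone. Going by these compounds, whether an amine or a carboxylic acid in place of that fluorine would move the number stays open.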